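From Methyl to Bromo on a Shared Core

The source may report more compounds than this note shows. Statements on the series, on what has been measured and on what is new or still open speak of the compounds shown alone.

Compound 1, `C#CCSc1nc(Nc2cccc(Cl)c2)c(C#N)c(-c2ccccc2)n1`, gives 10500 nM in a functional assay on B16-F10 cells (Mus musculus) for inhibition, read by MTT assay, with a stated time of 72 h; a lower number here means a stronger inhibitor, a higher number a weaker inhibitor.
Compound 2, `Cc1ccc(Nc2nc(SCc3cn(Cc4ccc(F)cc4)nn3)nc(-c3ccccc3)c2C#N)cc1`, gives 3040 nM in this assay.
Compound 3, `Cc1ccc(Nc2nc(SCc3cn(Cc4ccccc4Cl)nn3)nc(-c3ccc(C)cc3)c2C#N)cc1`, gives 2630 nM in this assay.

Compound 3 has the lowest of the three numbers, yet its gap to compound 2 lies within the scatter, so the two cannot be ordered; only compound 1 sits clearly higher. Compound 4, `Cc1ccc(Nc2nc(SCc3cn(Cc4ccccc4Cl)nn3)nc(-c3ccc(Br)cc3)c2C#N)cc1`, has not been measured. It differs from compound 3 in one place: bromo in place of methyl on an aromatic carbon. Within the data shown here, no measured pair shows this exchange, so the step is expected to be small, with no direction beyond the scatter. The expected step is a 1.1-fold lower number from compound 3 to compound 4 (0.02 log units; within the scatter). Compound 4 is estimated at 2500 nM, between 1000 nM and 6500 nM.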

Compound 4, half-maximal inhibitory concentration: 2870 nM
Beside the measured number, compound 4's estimate is 1.1-fold (0.06 log units) below it; measured number inside the range.
By their numbers in this assay, from the lowest: compounds 3, 4 and 2 (each within the scatter of the next); then compound 1.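

In this assay the exchange of 4-methylphenyl for 4-bromophenyl is a 1.1-fold higher number from compound 3 to compound 4 (0.04 log units; within the scatter) and so leaves the two compounds impossible to order. Among these compounds, this is the first pair here that differs in one place, and it shows that bromo can stand in place of methyl at this position with no readable difference in the number. No further measurement bears on this result. Open remains how a methoxy group, an amine or a carboxylic acid would read at this position.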